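The compounds below may be only part of what the source reports. "The series", "measured", "known", "first", "only" and "open" are said of these compounds alone.

Measured compounds in an assay on membranes from brain for binding affinity to Lysophosphatidylserine lipase ABHD12 (Mus musculus), read by fluorescence, with a stated time of 20 min; a higher number here means a weaker inhibitor, a lower number a stronger inhibitor:
- compound 1 `Cc1c(Oc2ccc(OC(F)(F)F)cc2)ccnc1N1CCC(NC(=S)Nc2cccnc2)CC1` gives 26 nM
- compound 2 `S=C(Nc1cccnc1)NC1CCN(c2cc(OC3CCCCC3)ccn2)CC1` gives 3400 nM
- compound 3 `FC(F)(F)Oc1ccc(Oc2ccnc(N3CCC(NC(=S)Nc4cccnc4)CC3)c2)cc1` gives 410 nM

Compound 3 stands second highest of the three numbers, between compound 1 and compound 2. The two single-change steps recorded are a 16-fold higher number from compound 1 to compound 3 (1.20 log units; beyond the scatter) and an 8.3-fold lower number from compound 2 to compound 3 (0.92 log units; beyond the scatter); both lie beyond the scatter.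

Compound 4 `S=C(Nc1cccnc1)NC1CCN(c2cc(OCc3ccccc3)ccn2)CC1` differs from compound 3 in one place: benzyl in place of 4-(trifluoromethoxy)phenyl on an oxygen on an aromatic ring. The step that bears on this change is an 8.3-fold lower number from compound 2 to compound 3 (0.92 log units; beyond the scatter), in which replacing cyclohexyl by 4-(trifluoromethoxy)phenyl on the same oxygen lowered the number by a modest amount. Benzyl is neither of those groups, so the direction is uncertain; the only guide is that the aromatic substituent on this oxygen gave the lower number and the non-aromatic one the higher. A step upward of modest size, toward compound 2 but short of it, is expected, with a real chance of no step beyond the scatter.

The expected step is a 3.7-fold higher number from compound 3 to compound 4 (0.56 log units; beyond the scatter). Compound 4 is expected at 1500 nM, with a range from 400 nM to 5000 nM.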

Compound 4, half-maximal inhibitory concentration: 2800 nM
Beside the measured number, compound 4's estimate is 1.9-fold (0.27 log units) below it, and the stated range covers the measured number.
By their numbers in this assay, from the lowest: compound 1; then compound 3; then compounds 4 and 2 (each within the scatter of the next).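

In this assay, benzyl on this oxygen gives a 6.8-fold higher number from compound 3 to compound 4 (0.83 log units; beyond the scatter), and it keeps the six-membered aromatic ring of carbon only, so having that ring in the group is not enough to reach the lower number of compound 3. Compound 4 thus goes against the earlier reading that an aromatic group here gives the lower number and a non-aromatic one the higher: benzyl and cyclohexyl cannot be told apart, with a 1.2-fold lower number from compound 2 to compound 4 (0.08 log units; within the scatter). No measurement shown accounts for these results.

Benzyl differs from 4-(trifluoromethoxy)phenyl both in its methylene link to the oxygen and in lacking the trifluoromethoxy group, and an unsubstituted phenyl on this oxygen would separate the two. As far as these compounds go, whether the methyl on the aromatic carbon that separates compound 1 from compound 3 acts in the same way with benzyl on the oxygen also stays open.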